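A few compounds are considered here, and "the series" means these few. Any claim that something is new, unique, unknown or untested is made for them only; others in the source may bear on it.

Measured in a functional assay on HepG2 cells (Homo sapiens) for inhibition, with a stated time of 72 h; on this read-out lower numbers stand for stronger inhibition and higher numbers for weaker inhibition:
Compound 1 `Cc1ccc(C)c(NC(=O)Nc2nc(Sc3c[nH]c4ccccc34)cc(N3CCCCC3)n2)c1`: 6440 nM
Compound 2 `O=C(Nc1ccccc1)Nc1nc(Nc2ccccc2)cc(Sc2c[nH]c3ccccc23)n1`: 14400 nM
Compound 3 `Cc1ccc(NC(=O)Nc2nc(Nc3ccccc3)cc(Sc3c[nH]c4ccccc34)n2)cc1`: 14900 nM

Compound 2 cannot be told apart from compound 3, while compound 1 shows a lower number than compound 2, a gap beyond the scatter. Compound 4 `O=C(Nc1ccccc1)Nc1nc(Sc2c[nH]c3ccccc23)cc(N2CCCCC2)n1` is compound 2 with piperidin-1-yl in place of anilino on an aromatic carbon.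

Going by the values given here, no measured step isolates this swap. Among the compounds with values here, the only step available, a 1.0-fold higher number from compound 2 to compound 3 (0.01 log units; within the scatter), is methyl in place of hydrogen on an aromatic carbon, a different change, and it stays within the scatter. It hints that a methyl group need not shift the number. Compound 1, at 6440 nM, already carries piperidin-1-yl and differs from compound 4 by methyl groups, so it is the closest guide. A lower number than for compound 2 is therefore expected, landing near compound 1. The expected change is a 1.8-fold lower number from compound 2 to compound 4 (0.27 log units; within the scatter). For compound 4 the estimated value is 7800 nM, with an expected range of 3500 nM to 16000 nM.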

Compound 4, half-maximal inhibitory concentration: 20900 nM
Estimate against measurement, compound 4: 2.7-fold (0.43 log units) below; the measured number lies above the stated range.
By their numbers in this assay, from the lowest: compound 1; then compounds 2, 3 and 4 (each within the scatter of the next).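

In this assay, piperidin-1-yl in place of anilino gives a 1.5-fold higher number from compound 2 to compound 4 (0.16 log units; within the scatter), so at this position the swap of a non-aromatic ring for an aromatic one, with the loss of the anilino hydrogen-bond donor, leaves a number that cannot be told from that of compound 2. With piperidin-1-yl held in place, phenyl in place of 2,5-dimethylphenyl gives a 3.2-fold higher number from compound 1 to compound 4 (0.51 log units; beyond the scatter), which ties the lower number of compound 1 to the 2,5-dimethylphenyl group and not to piperidin-1-yl. Nothing available explains either step.

From the compounds shown here alone, it stays open whether morpholin-4-yl or an open-chain amine such as dimethylamino would fit this position equally well. It is also unknown whether 2,5-dimethylphenyl would lower the number with anilino in place of piperidin-1-yl.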